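A few compounds are considered here, and "the series" means these few. Any claim that something is new, unique, unknown or untested is made for them only; others in the source may bear on it.

Measured compounds:
- compound 1, `CCCCCCCCCCCCCCNC(=O)[C@@H](NC(=O)c1ccccc1)[C@@H](C)O`: 54200 nM
- compound 2, `CCCCCCCCCCCCCCNC(=O)[C@@H](NC(=O)c1cc2ccccc2[nH]1)[C@@H](C)O`: 10500 nM

In a functional assay on HepG2 cells (Homo sapiens) for cytotoxicity, read by MTT assay, with a stated time of 48 h (a lower number here means a stronger inhibitor, a higher number a weaker inhibitor), compound 2 gives 10500 nM, the lowest number of the two, with compound 1 as its nearest neighbour at 54200 nM. Among the measured compounds shown here, the one step so far, a 5.2-fold lower number from compound 1 to compound 2 (0.71 log units; beyond the scatter), came from putting 1H-indol-2-yl in place of phenyl on the carbonyl carbon.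

Compound 3, `CCCCCCCCCCCCCCNC(=O)[C@@H](NS(=O)(=O)c1ccc(C)cc1)[C@@H](C)O`, differs from compound 2 by (4-methylphenyl)sulfonyl in place of (1H-indol-2-yl)carbonyl on an amine nitrogen. For the measured compounds named here, this change removes the group that carried the lowering step, so the one step that bears on it, a 5.2-fold lower number from compound 1 to compound 2 (0.71 log units; beyond the scatter), points back toward the number of compound 1. For compound 3 the expected step is a 3.8-fold higher number from compound 2 to compound 3 (0.58 log units; beyond the scatter), a rise beyond the scatter. Compound 3 is therefore estimated at 40000 nM, with a range from 12000 nM to 130000 nM.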

Compound 3, half-maximal inhibitory concentration: 10900 nM
The estimate for compound 3 lay 3.7-fold (0.56 log units) above the measured number, outside the stated range (below it).
By their numbers in this assay, from the lowest: compounds 2 and 3 (each within the scatter of the next); then compound 1.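

On the amine nitrogen, the lower number is not tied to the 1H-indol-2-yl group: in this assay, (4-methylphenyl)sulfonyl in its place gives a 1.0-fold higher number from compound 2 to compound 3 (0.02 log units; within the scatter) even though the entering group has no five-membered aromatic ring and no hydrogen-bond donor. Set against benzoyl, the same (4-methylphenyl)sulfonyl gives a 5.0-fold lower number from compound 1 to compound 3 (0.70 log units; beyond the scatter) and so matches the step seen with the indole group, which means that two quite different groups at this place both part from benzoyl. No measurement here explains why they do so.

On these data alone, it remains open whether a small acetyl group or a plain methanesulfonyl group on this nitrogen would hold the number at this level. As far as these compounds go, it is also open how much of the cytotoxicity depends on the long chain, which a shorter chain on the amide would test.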